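The source may hold more compounds than are shown below. What is called first, only, known or untested is meant among the compounds shown, and "the series" means these compounds.

Compound 2 `CCCCN(CCCC)CN1C(=O)/C(=N\c2ncc(Cc3cc(OC)c(OC)c(OC)c3)c(N)n2)c2cc(Cl)ccc21` gives 62.6 ug/mL in an ADME assay on MT4 cells (Homo sapiens) for cytotoxicity, read by MTT assay, with a stated time of 5 days; on this read-out higher numbers stand for lower toxicity in this test and lower numbers for higher toxicity in this test. Its nearest neighbour is compound 1 `COc1cc(Cc2cnc(/N=C3\C(=O)N(CN4CCCCC4C)c4ccc(Cl)cc43)nc2N)cc(OC)c1OC`, which in this assay gives 97.3 ug/mL. Going by the values given here, the step from one to the other, a 1.6-fold lower number from compound 1 to compound 2 (0.19 log units; within the scatter), is the only measured single-point change available, and it lies within the scatter. A third member of the series, compound 3 `COc1cc(Cc2cnc(/N=C3\C(=O)N(CN4CCN(c5c(F)cc6c(=O)c(C(=O)O)cn(C7CC7)c6c5F)CC4C)c4ccc(Cl)cc43)nc2N)cc(OC)c1OC`, carries a much larger group on the same saturated chain carbon, but in this assay compound 3 has "not determined" (no result reported), so no number for it was reported.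

The new compound, compound 4 `CCN(CC)CN1C(=O)/C(=N\c2ncc(Cc3cc(OC)c(OC)c(OC)c3)c(N)n2)c2cc(Cl)ccc21`, differs from compound 2 in one place: diethylamino in place of dibutylamino on a saturated chain carbon bound to an amide-type nitrogen in a ring. Among the compounds with values here, the one measured step that bears on this position, from compound 1 to compound 2, exchanged a ring-bearing amine for an open-chain one and produced no change beyond the scatter. Shortening the open chains from dibutylamino to diethylamino is a smaller edit still, so no step beyond the scatter is expected in this assay.

Compound 4 is therefore estimated to give 80 ug/mL, within a range from 40 ug/mL to 160 ug/mL. The expected step of a 1.3-fold higher number from compound 2 to compound 4 (0.11 log units; within the scatter) is judged to be inside the ordinary variation of such measurements.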

Compound 4, half-maximal cytotoxic concentration: 79.1 ug/mL
Compound 4: the middle estimate sits 1.0-fold (0.00 log units) above what was measured; measured number inside the range.
By their numbers in this assay, from the lowest: compounds 2, 4 and 1 (each within the scatter of the next).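

In this assay, both new steps stay within the scatter, whether the two open-chain amines are compared (a 1.3-fold higher number from compound 2 to compound 4 (0.10 log units; within the scatter)) or the ring-bearing amine is set against the shorter open-chain one (a 1.2-fold lower number from compound 1 to compound 4 (0.09 log units; within the scatter)). The single earlier step had shown only that one ring-bearing amine and one open-chain amine could not be told apart; the result now adds that going from the 9 heavy atoms of dibutylamino to the 5 of diethylamino, on a saturated chain carbon bound to an amide-type nitrogen in a ring, is not resolved by this read-out either, so 2-methylpiperidin-1-yl, dibutylamino and diethylamino cannot be ranked here. No measurement at hand speaks to what lies behind this result.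

As far as these compounds go, it remains open whether a morpholine, a piperazine, a carboxylic acid or a chain longer than those in dibutylamino at this place would give a step beyond the scatter. The three compounds with numbers also share one core, so they cannot show whether these amines would remain indistinguishable on a different one.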